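Swapping 3-chlorophenyl for 4-methylphenyl in a cell assay

This account rests on a few compounds, and the source may have more. Where it says the series, first, only, none or still open, it means among the compounds named here.

Measured in a functional assay on PC-3 cells (Homo sapiens) for cytotoxicity, read by MTT assay, with a stated time of 72 h; on this read-out higher numbers stand for weaker inhibition and lower numbers for stronger inhibition:
- Compound 1 `CNC(=O)c1cc(Oc2ccc(NC(=O)c3nccc(-c4ccc([N+](=O)[O-])cc4)n3)cc2)ccn1` gives > 100000 nM (a limit of the assay)
- Compound 2 `CNC(=O)c1cc(Oc2ccc(NC(=O)c3nccc(-c4cccc(Cl)c4)n3)cc2)ccn1` gives 20800 nM
- Compound 3 `CNC(=O)c1cc(Oc2ccc(NC(=O)c3nccc(-c4ccc(OC)cc4)n3)cc2F)ccn1` gives 24300 nM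

Within the data shown here, compound 2 and compound 3 provide the only actual numbers so far, and they lie within the usual scatter of each other. The reading for compound 1 is a limit, not a number.

Next comes compound 4 `CNC(=O)c1cc(Oc2ccc(NC(=O)c3nccc(-c4ccc(C)cc4)n3)cc2)ccn1`, which keeps the rest of compound 2 but carries 4-methylphenyl in place of 3-chlorophenyl, on an aromatic carbon of a six-membered aromatic ring with 2 nitrogen (4-methylphenyl in place of 3-chlorophenyl on an aromatic carbon).

Among the measured compounds shown here, one measured step touches this same place: an at least 4.8-fold lower number from compound 1 to compound 2 (0.68 log units; beyond the scatter), with 3-chlorophenyl in place of 4-nitrophenyl. It shows that a change here can move the reading in this assay, but it cannot show how 4-methylphenyl will read. With compound 2 at 20800 nM as the starting point, a large shift is not expected, and the best guess is a slightly higher number that stays within the scatter. The expected step is a 1.3-fold higher number from compound 2 to compound 4 (0.13 log units; within the scatter). For compound 4 the estimated value is 28000 nM, with an expected range of 11000 nM to 75000 nM.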

Compound 4, half-maximal inhibitory concentration: 13100 nM
The estimate for compound 4 lay 2.1-fold (0.33 log units) above the measured number; the range from low to high includes it.
By their numbers in this assay, from the lowest: compounds 4, 2 and 3 (each within the scatter of the next). At a limit, above all of these: compound 1.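

In this assay, 4-methylphenyl in place of 3-chlorophenyl gives a 1.6-fold lower number from compound 2 to compound 4 (0.20 log units; within the scatter), so these two groups, each with 7 heavy atoms and no hydrogen-bond donors or acceptors, cannot be told apart at this position. With methyl in place of nitro on an aromatic carbon, the reading shows an at least 7.6-fold lower number from compound 1 to compound 4 (0.88 log units; beyond the scatter), so compound 1, with its 4-nitrophenyl, now stands apart from both compound 2 and compound 4 at this position. The true size of that gap stays unknown because the reading of compound 1 is a limit, not a number: the limit of > 100000 nM in this assay, at which 1 of the 4 values shown sits.

Since 3-chlorophenyl and 4-methylphenyl differ both in the group on the phenyl ring and in where it sits, the compounds shown cannot separate those two changes, and they do not reveal why the 4-nitrophenyl compound stands apart. They also leave open how this position would read with a phenyl ring carrying an amine or a carboxylic acid, or with a longer chain in place of the phenyl ring.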